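Naphthalenyl in place of bromophenyl on a shared core

The source may hold more compounds than are shown below. What is called first, only, known or untested is meant among the compounds shown, and "the series" means these compounds.

Compound 1 `CC(C)(C)c1ccc(CNCCCNS(=O)(=O)c2cc(C(F)(F)F)cc(C(F)(F)F)c2)cc1`: 2900 nM
Compound 2 `O=S(=O)(NCCCNCc1ccc(Br)cc1)c1cc(C(F)(F)F)cc(C(F)(F)F)c1`: 2600 nM

In a functional assay on A2780 cells (Homo sapiens) for inhibition, read by MTT assay, with a stated time of 72 h (on this read-out higher numbers stand for weaker inhibition of growth and lower numbers for stronger inhibition of growth), compound 1 gives 2900 nM and compound 2 gives 2600 nM. Compound 2 holds the lower of the two numbers, but the step of a 1.1-fold lower number from compound 1 to compound 2 (0.05 log units; within the scatter) lies within the scatter, so neither compound can be called the stronger. Compound 3 `O=S(=O)(NCCCNCc1cccc2ccccc12)c1cc(C(F)(F)F)cc(C(F)(F)F)c1` differs from compound 2 in one place: naphthalen-1-yl in place of 4-bromophenyl on a saturated chain carbon bound to an amine nitrogen. Going by the values given here, the single measured step concerns a different change and is itself within the scatter, so it gives no direction for this one. Compound 3 is therefore expected to show a 1.0-fold lower number from compound 2 to compound 3 (0.02 log units; within the scatter). Compound 3 is estimated at 2500 nM, with a range of 1000 nM to 6500 nM.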

Compound 3, concentration for 50% growth inhibition: 3100 nM
Compound 3: middle estimate off by 1.2-fold (0.09 log units), on the low side; low and high end bracket the measured number.
By their numbers in this assay, from the lowest: compounds 2, 1 and 3 (each within the scatter of the next).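

In this assay the saturated chain carbon bound to an amine nitrogen now carries naphthalen-1-yl as well as the two substituted phenyl groups, with a 1.2-fold higher number from compound 2 to compound 3 (0.08 log units; within the scatter) and with a 1.1-fold higher number from compound 1 to compound 3 (0.03 log units; within the scatter) as the two steps. Replacing one six-membered aromatic ring with two therefore produces no change that can be read at this place. Nothing at hand bears on why this is so. The compounds shown leave open whether a pyridine ring or a cyclohexyl ring at this place would move the number beyond the scatter. They also leave open what a longer chain linking the amine and the sulfonamide would do.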